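Moving the sulfonamide from ring nitrogen to ring carbon

The source may report more compounds than this note shows. Statements on the series, on what has been measured and on what is new or still open speak of the compounds shown alone.

Measured compounds:
Compound 1 `CS(=O)(=O)N1CCN(C2CN(CCC3(c4ccc(Cl)c(Cl)c4)CCC(=O)N(CC4CC4)C3)C2)CC1` gives 3.16 nM in an assay on isolated protein (artery, Oryctolagus cuniculus) with Substance-P receptor (Homo sapiens) as the target; a lower number here means tighter binding, a higher number weaker binding.
Compound 2 `CNS(=O)(=O)N1CCN(C2CN(CCC3(c4ccc(Cl)c(Cl)c4)CCC(=O)N(CC4CC4)C3)C2)CC1` gives 3.16 nM in this assay.
Compound 3 `NC(=O)N1CCN(C2CN(CCC3(c4ccc(Cl)c(Cl)c4)CCC(=O)N(CC4CC4)C3)C2)CC1` gives 5.01 nM in this assay.

On the numbers shown, compound 3 cannot be separated from the other two: a 1.6-fold higher number from compound 1 to compound 3 (0.20 log units; within the scatter) and a 1.6-fold higher number from compound 2 to compound 3 (0.20 log units; within the scatter), and likewise no change at the digits printed from compound 1 to compound 2 (within the scatter). All three share the same core and differ only in the group on the ring nitrogen of the piperazine, and none of those swaps moved the number beyond the scatter.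

Compound 4 `CS(=O)(=O)NC1CCN(C2CN(CCC3(c4ccc(Cl)c(Cl)c4)CCC(=O)N(CC4CC4)C3)C2)CC1` has not yet been measured. Its change is 4-(methanesulfonamido)piperidin-1-yl in place of 4-carbamoylpiperazin-1-yl on a saturated ring carbon. Among the measured compounds shown here, no measured step covers exactly this exchange, since here the ring itself changes and the sulfonyl group now hangs on a nitrogen attached to a ring carbon rather than on the ring nitrogen. The three measured steps, all within the scatter, bear on it only loosely: they suggest that this end of the molecule tolerates varied small polar groups. The step from compound 3 to compound 4 is therefore expected to be small, a 1.1-fold lower number from compound 3 to compound 4 (0.05 log units; within the scatter), with a wide range allowed for the change of ring. Compound 4 is expected to give about 4.5 nM in this assay, between 1.5 nM and 14 nM.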

Compound 4, dissociation constant: 10 nM
Compound 4: middle estimate off by 2.2-fold (0.35 log units), on the low side; measured number inside the range.
By their numbers in this assay, from the lowest: compounds 1, 2, 3 and 4 (each within the scatter of the next, the first and the last beyond it).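

In this assay, among the compounds shown here, the swap at this position gives the first steps beyond the scatter: a 3.2-fold higher number from compound 1 to compound 4 (0.50 log units; beyond the scatter) and a 3.2-fold higher number from compound 2 to compound 4 (0.50 log units; beyond the scatter), both modest and both towards weaker binding. For the compounds shown here, the exchanges among groups on the piperazine nitrogen had produced no such step, so this end of the molecule is less indifferent to change than those compounds alone suggested. Compound 4 still cannot be separated from the carbamoyl compound, with a 2.0-fold higher number from compound 3 to compound 4 (0.30 log units; within the scatter), so the 4-(methanesulfonamido)piperidin-1-yl group costs binding only against the two sulfonyl-bearing piperazines, and nothing shown gives a reason for the difference.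

Compound 4 changes the ring and moves the sulfonyl group onto a nitrogen attached to a ring carbon in a single exchange, so the compounds shown cannot say which of these two changes accounts for the weaker binding. They also leave open how this position would respond to a piperidine bearing a simple amine or a carboxylic acid in place of the methanesulfonamido group, or to a longer chain on the sulfonyl sulfur.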